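One carbon shorter on the chain of compound 2

A few compounds are considered here, and "the series" means these few. Any claim that something is new, unique, unknown or untested is made for them only; others in the source may bear on it.

Compound 1, `C[Se]c1ccc(N(C)c2nc(C)nc3ccccc23)cc1C`: 8 nM
Compound 2, `COc1ccc(N(C)c2nc(C)nc3ccccc23)cc1OCCCCC[Se]C#N`: 3560 nM
Compound 3, `CN(c1ccc([Se]C#N)cc1)c1nc(C2CC2)nc2ccccc12`: 51 nM

Of the compounds shown here, three sharing the same core have been measured in a functional assay on RKO cells (Homo sapiens) for inhibition, read by MTT assay, with a stated time of 48 h; a higher number here means a weaker inhibitor, a lower number a stronger inhibitor. Compound 2 gives 3560 nM in this assay, the highest of the three numbers; compound 3 is its nearest neighbour and compound 1 its furthest, and both gaps lie beyond the scatter of repeated measurements, so compound 2 is the weakest inhibitor of the three as measured.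

Compound 4, `COc1ccc(N(C)c2nc(C)nc3ccccc23)cc1OCCCC[Se]C#N`, has not yet been measured. It differs from compound 2 in one place: a group of 3 heavy atoms (1 carbon, 1 nitrogen, 1 selenium; no ring) in place of a group of 4 heavy atoms (2 carbon, 1 nitrogen, 1 selenium; no ring), on a saturated chain carbon, four bonds along the chain from an oxygen on an aromatic ring. For the measured compounds named here, no pair of measured compounds shows this change on its own, so there is no measured step to lean on. Since the shared core and the rest of compound 2 are untouched, the step in this assay is expected to be a 1.2-fold lower number from compound 2 to compound 4 (0.07 log units; within the scatter), which would leave it within the usual scatter. Compound 4 is therefore estimated at 3000 nM in this assay, with a range from 1200 nM to 8000 nM.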

Compound 4, half-maximal inhibitory concentration: 1360 nM
For compound 4 the middle estimate is 2.2-fold (0.34 log units) above the measured one, and the stated range covers the measured number.
By their numbers in this assay, from the lowest: compound 1; then compound 3; then compound 4; then compound 2.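

In this assay, the chain of compound 2 proves sensitive to its length: a group of 3 heavy atoms (1 carbon, 1 nitrogen, 1 selenium; no ring) in place of a group of 4 heavy atoms (2 carbon, 1 nitrogen, 1 selenium; no ring) gives a 2.6-fold lower number from compound 2 to compound 4 (0.42 log units; beyond the scatter). For the compounds shown here, this is the only step here that changes a single place, and although modest, it shows that this saturated chain carbon is not a neutral site for the change. No measurement available here accounts for the step.

A single step cannot show whether the trend continues with a still shorter chain or reverses with a longer chain. It also leaves open what an amine or a carboxylic acid at the end of the chain would do in place of the selenium-bearing group.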